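Phenyl for Benzyl on the Amide Nitrogen: Cytotoxicity Outlook

This account rests on a few compounds, and the source may have more. Where it says the series, first, only, none or still open, it means among the compounds named here.

Compound 3 `CC(CSc1nnc(-c2ccncc2)s1)C(=O)NCc1ccccc1` carries a benzyl group on its amide nitrogen and a branched chain leading to the shared core. In an ADME assay on BHK-21 cells (Mesocricetus auratus) for cytotoxicity, with a stated time of 3 days (a lower number here means that less compound is tolerated, a higher number that more compound is tolerated), compound 3 gives > 50000 nM, which is a limit of the assay and not a number. Compound 1 `O=C(CCSc1nnc(-c2ccncc2)s1)Nc1ccccc1` has an unbranched chain and a phenyl on the amide nitrogen. In this assay compound 1 gives > 50000 nM, again a limit rather than a measured value. Compound 2 `CC(CSc1nnc(-c2ccncc2)s1)C(=O)NCc1ccc(Cl)cc1` has no result in this assay, its entry reading "not determined" (no result reported). Where compound 3 stands is therefore only at the ceiling of the assay: the limit of > 50000 nM in this assay, at which 2 of the 3 values shown sit.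

Compound 4 `CC(CSc1nnc(-c2ccncc2)s1)C(=O)Nc1ccccc1` differs from compound 3 by phenyl in place of benzyl on an amide-type nitrogen, which reads benzylamino to anilino one bond further out. Among the measured compounds shown here, no step between measured compounds is known in this assay. The step that the limit leaves unreadable from compound 3 to compound 4 is expected to be none beyond the scatter. Compound 4 is estimated at 70000 nM, within a range from 30000 nM to 200000 nM, most likely reported as a limit again.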

Compound 4, half-maximal cytotoxic concentration: > 50000 nM
Compound 4: no number, only a limit (the forecaster's own chance of this, stated with the estimate: 80%); the middle value is on the limit's open side.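

Compound 1, compound 3 and compound 4 each give only a limit in this assay, so no step to compound 4 can be read: the limit of > 50000 nM in this assay, at which 3 of the 4 values shown sit.

The compounds shown leave open whether phenyl in place of benzyl on the amide-type nitrogen changes how much compound is tolerated.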